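The source may report more compounds than this note shows. Statements on the series, on what has been measured and on what is new or still open speak of the compounds shown alone.

Measured compounds:
compound 1 `COc1cc(/C=C/C(=O)c2cccc(-n3cc(-c4ccc(Cl)cc4)[nH]c3=O)c2)cc(OC)c1OC` gave 5960 nM
compound 2 `O=C(/C=C/c1cccc(O)c1)c1cccc(-n2cc(-c3ccccc3)[nH]c2=O)c1` gave 6140 nM
compound 3 `O=C(/C=C/c1cccc(O)c1)c1cccc(-n2cc(-c3ccc(Cl)cc3)[nH]c2=O)c1` gave 4000 nM

All three were tested in a functional assay on Hs-578T cells (Homo sapiens) for inhibition; a higher number here means a weaker inhibitor of growth, a lower number a stronger inhibitor of growth. Compound 3 and compound 2 differ by hydrogen in place of chloro on an aromatic carbon, and this gave a 1.5-fold higher number from compound 3 to compound 2 (0.19 log units; within the scatter). Compound 1 and compound 3 carry the same 4-chlorophenyl group, but the difference between the two cores is not broken down here; their values lie within the scatter of each other.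

Compound 4 `COc1cc(/C=C/C(=O)c2cccc(-n3cc(-c4ccccc4)[nH]c3=O)c2)cc(OC)c1OC` has not yet been measured. It differs from compound 1 by hydrogen in place of chloro on an aromatic carbon, the same change as between compound 3 and compound 2, made at the same kind of place. Resting on the earlier step, which was a 1.5-fold higher number from compound 3 to compound 2 (0.19 log units; within the scatter), the expected step in this assay is a 1.4-fold higher number from compound 1 to compound 4 (0.15 log units; within the scatter). Compound 4 is therefore estimated at 8500 nM, most likely between 4500 nM and 16000 nM.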

Compound 4, concentration for 50% growth inhibition: 3410 nM
Compound 4: middle estimate off by 2.5-fold (0.40 log units), on the high side, and the stated range ends above it.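

In this assay, hydrogen in place of chloro gave a 1.7-fold lower number from compound 1 to compound 4 (0.24 log units; within the scatter). Set beside the earlier step, the same change did not carry over from one core to the other as a fixed step: the same change on two cores in this assay, a 1.5-fold higher number (0.19 log units; within the scatter) from compound 3 to compound 2 and a 1.7-fold lower number (0.24 log units; within the scatter) from compound 1 to compound 4, 2.7-fold (0.43 log units) apart, beyond the scatter of two such steps Each step alone lies within the scatter, however, so the pair does not establish that the change truly acts in opposite directions on the two cores, and it gives no reason for the gap.

The compounds shown leave open how a fluoro, a bromo or an amine at the same place on the phenyl ring would read on either core. They also leave open whether the gap would recur on further cores.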